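The source may hold more compounds than are shown below. What is called first, only, known or untested is meant among the compounds shown, and "the series" means these compounds.

Of the compounds shown here, three built on one shared core have been tested in a functional assay on NCI-H1975 cells (Homo sapiens) for inhibition, read by MTT assay, with a stated time of 72 h; on this read-out lower numbers stand for stronger inhibition and higher numbers for weaker inhibition. Compound 1 `O=C(CSc1nc(Nc2ccccc2)c2ccccc2n1)Nc1ccc([N+](=O)[O-])cc1` gives 13000 nM. Compound 2 `O=C(CSc1nc(Nc2ccccc2)c2ccccc2n1)Nc1ccc(Cl)cc1Cl` gives 8410 nM. Among the compounds with values here, the only pair of measured compounds that differ in a single place is this one, and its step, a 1.5-fold lower number from compound 1 to compound 2 (0.19 log units; within the scatter), concerns a group on an amide-type nitrogen. Compound 3 `C=CC(=O)Nc1cccc(NC(=O)CSc2nc(Nc3cccc(Cl)c3)c3ccccc3n2)c1` gives 9460 nM, which is the second highest of the three numbers; compound 2 sits nearest to it and compound 1 furthest, and both gaps lie within the scatter, so the three measured compounds cannot be told apart on this read-out.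

Compound 4 `C=CC(=O)Nc1cccc(NC(=O)CSc2nc(Nc3ccc(CC)cc3)c3ccccc3n2)c1` has not yet been measured in this assay. It differs from compound 3 by 4-ethylphenyl in place of 3-chlorophenyl on a nitrogen on an aromatic ring. Within the data shown here, no measured step touches this nitrogen on the aromatic ring; the one step available sits elsewhere, on the amide-type nitrogen, and it stayed within the scatter. With nothing to point in either direction, the expectation for compound 4 is a step of a 1.0-fold higher number from compound 3 to compound 4 (0.00 log units; within the scatter), that is, no change beyond the scatter. Compound 4 is therefore estimated at 9500 nM, with a likely range from 4000 nM to 22000 nM.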

Compound 4, half-maximal inhibitory concentration: 8270 nM
Compound 4: the middle estimate sits 1.1-fold (0.06 log units) above what was measured; the measured number falls inside the stated range.
By their numbers in this assay, from the lowest: compounds 4, 2, 3 and 1 (each within the scatter of the next).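

Within the data shown here, this is the first measured step at the nitrogen on an aromatic ring: in this assay, putting 4-ethylphenyl in place of 3-chlorophenyl gives a 1.1-fold lower number from compound 3 to compound 4 (0.06 log units; within the scatter). The change swaps a chlorine for a two-carbon ethyl group and also alters where that group sits on the phenyl ring, yet the result stays within the scatter, so this particular exchange cannot be told apart from no change on this read-out. The other measured step, at the amide-type nitrogen, a 1.5-fold lower number from compound 1 to compound 2 (0.19 log units; within the scatter), also stays within the scatter, and nothing available explains why either exchange leaves the number so little moved.

From the compounds shown here alone, two compounds make a very thin sample of this nitrogen, and it remains open whether a phenyl ring carrying an amine, a carboxylic acid or a chain longer than ethyl would move the number beyond the scatter. Also open, going by these compounds, is how a plain phenyl on this nitrogen would compare with the rest of compound 3 kept the same, which would help show whether the chlorine or the ethyl group matters at all.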